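The source may hold more compounds than are shown below. What is called first, only, known or untested is meant among the compounds shown, and "the series" means these compounds.

In a functional assay on A549 cells (Homo sapiens) for antiproliferative activity, read by sulforhodamine B assay, with a stated time of 48 h (a higher number here means a weaker inhibitor of growth, a lower number a stronger inhibitor of growth), compound 1 `O=C(NNC(=S)Nc1ccccc1)C1=C(Cl)c2ccccc2CCC1` gives 4880 nM, compound 2 `ClC1=C(c2nnc(-c3ccccc3)o2)CCCc2ccccc21` gives 2270 nM, and compound 3 `Cc1ccc(-c2nnc(C3=C(Cl)c4ccccc4CCC3)o2)cc1` gives 3420 nM. Compound 3 thus lies within the scatter of both other compounds, so it holds no clear rank among them. Compound 4 `O=[N+]([O-])c1ccc(-c2nnc(C3=C(Cl)c4ccccc4CCC3)o2)cc1` differs from compound 3 by nitro in place of methyl on an aromatic carbon, para to a large group: nitro in place of methyl on an aromatic carbon. Within the data shown here, one measured step bears on this site, namely a 1.5-fold higher number from compound 2 to compound 3 (0.18 log units; within the scatter), where methyl took the place of hydrogen. That step stays within the scatter, so the site has shown little response so far. However, no nitro compound has been measured, so this single step is only a weak guide. A step no larger than the scatter is therefore expected in this assay, with no firm direction. The expected step is a 1.2-fold lower number from compound 3 to compound 4 (0.09 log units; within the scatter). For compound 4 the estimated value is 2800 nM, with an expected range from 1000 nM to 7000 nM.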

Compound 4, concentration for 50% growth inhibition: 2610 nM
Compound 4: the middle estimate sits 1.1-fold (0.03 log units) above what was measured; measured number inside the range.
By their numbers in this assay, from the lowest: compounds 2, 4, 3 and 1 (each within the scatter of the next, the first and the last beyond it).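

In this assay the site on the aromatic carbon para to a large group now carries a third group, and replacing methyl with nitro gives a 1.3-fold lower number from compound 3 to compound 4 (0.12 log units; within the scatter) while replacing hydrogen with nitro gives a 1.1-fold higher number from compound 2 to compound 4 (0.06 log units; within the scatter). Until now only methyl and hydrogen could be compared here, so the new result extends the picture to nitro, which has more heavy atoms than methyl and, unlike methyl, has hydrogen-bond acceptors; even so, neither step exceeds the usual scatter. No accompanying measurement helps explain why the numbers for these three compounds stay so close.

From the compounds shown here alone, it remains open whether an amine, a carboxylic acid or a longer chain at this same site would also stay within the scatter. Whether nitro on another carbon of that ring would behave in the same way is also unresolved.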